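Pyridin-3-yl in Place of 2-Fluorophenyl: An Expectation

The compounds below may be only part of what the source reports. "The series", "measured", "known", "first", "only" and "open" are said of these compounds alone.

Compound 1 `NC(=O)c1c(NC(=O)c2ccccc2Cl)sc2c1CCN(C(=S)Nc1ccccc1F)C2`: 28700 nM
Compound 2 `NC(=O)c1c(NC(=O)c2ccccc2Cl)sc2c1CCN(C(=O)Nc1cc(C(F)(F)F)cc(C(F)(F)F)c1)C2`: 38600 nM

Of the compounds shown here, two built on a shared core have been tested in a functional assay on HeLa cells (Homo sapiens) for antiproliferative activity, with a stated time of 24 h; a lower number here means a stronger inhibitor, a higher number a weaker inhibitor. Compound 1 gives 28700 nM there, and compound 2 gives 38600 nM. The gap between these two numbers lies within the usual scatter of repeated measurements, so neither compound can be called the stronger; both are weak inhibitors on this read-out.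

Compound 3 `NC(=O)c1c(NC(=O)c2ccccc2Cl)sc2c1CCN(C(=S)Nc1cccnc1)C2` has not yet been measured. It differs from compound 1 in one place: pyridin-3-yl in place of 2-fluorophenyl on an amide-type nitrogen. Among the measured compounds shown here, no pair of measured compounds shows a change of this kind, so its effect cannot be read from the numbers at hand. Since the two measured compounds sit within the scatter of each other, and the change here swaps one six-membered aromatic ring for another, the number for compound 3 is expected to move little, if at all, beyond the scatter. Compound 3 is therefore expected to give about 30000 nM in this assay, within a range from 12000 nM to 80000 nM. This corresponds to an expected step of a 1.0-fold higher number from compound 1 to compound 3 (0.02 log units; within the scatter), small and uncertain in direction.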

Compound 3, half-maximal inhibitory concentration: > 50000 nM
Compound 3 gave a limit, no number (the forecaster's own chance of this, stated with the estimate: 10%); middle value at least 1.6-fold (0.22 log units) away from the limit.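

In this assay compound 3 gives > 50000 nM, which is a limit of the assay and not a number. Putting pyridin-3-yl in place of 2-fluorophenyl on the amide-type nitrogen gives an at least 1.7-fold higher number from compound 1 to compound 3 (0.24 log units; that floor lies within the scatter), so this swap brings no gain in strength at this position, but the floor of the step is too small to prove a real loss. How large the step truly is stays unknown, and the reading rests on a single point that carries no exact value: the limit of > 50000 nM in this assay, at which 1 of the 3 values shown sits.

The swap changes two things at once, removing the fluorine and bringing a nitrogen into the ring, so the compounds shown leave open which of the two goes with the step; a plain phenyl on this amide-type nitrogen would separate them, and a pyridin-4-yl would show whether the place of the ring nitrogen matters. They also leave open whether a carboxylic acid or a longer alkyl chain at this position would give a stronger inhibitor than compound 1 in this assay.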